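A few compounds are considered here, and "the series" means these few. Any claim that something is new, unique, unknown or untested is made for them only; others in the source may bear on it.

Two members of the series have numbers in a functional assay on SK-OV-3 cells (Homo sapiens) for antiproliferative activity, read by MTT assay, with a stated time of 72 h; on this read-out lower numbers stand for stronger inhibition and higher numbers for weaker inhibition. Compound 1 `O=C(CCc1cccc2c1B(O)OC2)Nc1cccc(Br)c1` gives 540 nM and compound 2 `Cc1ccc(NC(=O)CCc2cccc3c2B(O)OC3)cc1Br` gives 600 nM. Going by the values given here, compound 1 stands lowest of the two, but the only step, a 1.1-fold higher number from compound 1 to compound 2 (0.05 log units; within the scatter), is within the scatter, so the pair is not told apart. Compound 3 `O=C(CCc1cccc2c1B(O)OC2)Nc1cccc(-c2ccc(C(F)(F)F)cc2)c1` is still to be measured. Against compound 1 the change is 4-(trifluoromethyl)phenyl in place of bromo on an aromatic carbon, placed on an aromatic carbon of a six-membered aromatic ring of carbon only, meta to a large group. Among the compounds with values here, the single measured step, a methyl for a hydrogen on the same ring, is a far smaller alteration than the exchange of a bromine for a 4-(trifluoromethyl)phenyl, so it offers little guidance beyond showing that a small addition on this ring left the number within the scatter. Within the data shown here, no measured step bears directly on the new group. The step is therefore expected to be modest and uncertain in direction: a 1.1-fold higher number from compound 1 to compound 3 (0.05 log units; within the scatter). Compound 3 is estimated at 600 nM, with a range from 150 nM to 2500 nM.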

Compound 3, half-maximal inhibitory concentration: 500 nM
Estimate against measurement, compound 3: 1.2-fold (0.08 log units) above; low and high end bracket the measured number.
By their numbers in this assay, from the lowest: compounds 3, 1 and 2 (each within the scatter of the next).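

In this assay, the aromatic carbon that holds bromo in compound 1 also takes a much larger group: 4-(trifluoromethyl)phenyl brings 10 heavy atoms and a six-membered aromatic ring of carbon only in place of 1 heavy atom, and the result is a 1.1-fold lower number from compound 1 to compound 3 (0.03 log units; within the scatter). The earlier pair covered only a methyl in place of hydrogen, whereas this exchange shows that neither bromo nor a small substituent at this carbon is required for a number in this range. Nothing available explains why the number holds across so large a change.

From the compounds shown here alone, how an amine or a carboxylic acid at this carbon would read remains open. Also open, going by these compounds, is whether the trifluoromethyl contributes at all, a question that a plain phenyl at this carbon would address.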